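Chloro to methyl on the shared core: lipophilicity notes

A few compounds are considered here, and "the series" means these few. Any claim that something is new, unique, unknown or untested is made for them only; others in the source may bear on it.

Of the compounds shown here, three have been measured so far and one has not. Compound 1 `CC(C)Nc1nc(NCc2ccco2)c2cccc(Cl)c2n1` gives 3.96 in a physicochemical assay for lipophilicity, at pH 7.4; on this read-out higher numbers stand for higher lipophilicity and lower numbers for lower lipophilicity. Compound 2 `CC(C)Nc1nc(NCc2ccco2)c2ccc(Cl)cc2n1` is built from the same atoms joined differently; the difference between the two cores is not broken down here. In this assay compound 2 gives 3.91, which lies within the scatter of the number for compound 1. Compound 3 `Cc1cccc2c(NCc3ccco3)nc(NC(C)C)nc12` gives 3.55 in this assay. Compound 3 differs from compound 1 by methyl in place of chloro on an aromatic carbon, and the step is a number 0.41 log units lower from compound 1 to compound 3 (beyond the scatter).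

Compound 4 `Cc1ccc2c(NCc3ccco3)nc(NC(C)C)nc2c1` awaits measurement in this assay. It differs from compound 2 by methyl in place of chloro on an aromatic carbon. The two place lines are not the same word for word: in compound 3 the methyl stands ortho to a fused ring and meta to a fused ring, whereas in compound 4 it stands meta to a fused ring and para to a fused ring, so the two swaps are the same kind of change rather than the same change. Going by the values given here, on this basis the step from compound 2 to compound 4 is expected to be a number 0.41 log units lower from compound 2 to compound 4 (beyond the scatter), beside the measured a number 0.41 log units lower from compound 1 to compound 3 (beyond the scatter), with the caveat that only one earlier instance of the swap exists and it sits at a different place. Compound 4 is therefore estimated at 3.5 in this assay. The range expected for compound 4 runs from 3.25 to 3.75.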

Compound 4, distribution coefficient: 3.61
The estimate for compound 4 lay 0.11 log units below the measured number; measured number inside the range.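

In this assay, going by these compounds alone, methyl in place of chloro on an aromatic carbon reads a number 0.30 log units lower from compound 2 to compound 4 (within the scatter) on the core of compound 2 and a number 0.41 log units lower from compound 1 to compound 3 (beyond the scatter) on the core of compound 1 so the swap carries the same sign at both places, but only one of the two steps stands clear of the scatter. What the pair supports is therefore modest: the step on the core of compound 2 does not go against the step on the core of compound 1, yet taken alone it cannot be told apart from repeat scatter, and two instances at two different places establish no general rule for the series, nor do they show whether the size of the swap depends on its place. Nothing at hand explains the reading at either place, and no measurement bears on its origin.

The compounds shown leave open how the shared core responds when fluoro, methoxy, nitrile or a carboxylic acid stands in place of chloro on these aromatic carbons. They also leave open whether methyl in place of chloro reads alike at the remaining aromatic carbons of the core, or when a longer chain replaces the isopropyl group on the amine.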